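Hydroxy to methoxy on the aryl group of compound 3

The compounds below may be only part of what the source reports. "The series", "measured", "known", "first", "only" and "open" are said of these compounds alone.

Three compounds of the series have numbers in a functional assay on P388 cells (Mus musculus) for cytotoxicity, read by MTT assay, with a stated time of 72 h; on this read-out lower numbers stand for stronger inhibition and higher numbers for weaker inhibition. Compound 1 `Cc1c(/N=C/c2ccc(N(C)C)cc2)c(=O)n(-c2ccccc2)n1C` gives 468000000 nM, compound 2 `COc1ccc(/C=N/c2c(C)n(C)n(-c3ccccc3)c2=O)cc1` gives 186000000 nM, and compound 3 `Cc1c(/N=C/c2cccc(O)c2)c(=O)n(-c2ccccc2)n1C` gives 437000000 nM. Compound 3 stands second highest of the three, close to compound 1 and separated from compound 2 by a step beyond the scatter.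

Compound 4 `COc1cccc(/C=N/c2c(C)n(C)n(-c3ccccc3)c2=O)c1` differs from compound 3 by methyl in place of hydrogen on an oxygen on an aromatic ring; read one bond further out, this is hydroxy to methoxy, 3-hydroxyphenyl to 3-methoxyphenyl.

Among the measured compounds shown here, no measured step changes hydroxy to methoxy alone. The step of a 2.3-fold higher number from compound 2 to compound 3 (0.37 log units; beyond the scatter) bears most closely, but it changes where the group sits as well as what it is. The step of a 2.5-fold lower number from compound 1 to compound 2 (0.40 log units; beyond the scatter) shows that a methoxy in place of a dimethylamino also shifts the number modestly. Both steps are modest and neither isolates the present change, so the expected step in this assay is small, toward a lower number, and may fall within the scatter.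

Compound 4 is expected to show a 1.6-fold lower number from compound 3 to compound 4 (0.19 log units; within the scatter). The estimate for compound 4 in this assay is 280000000 nM, with a range from 130000000 nM to 600000000 nM.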

Compound 4, half-maximal inhibitory concentration: 105000000 nM
The estimate for compound 4 lay 2.7-fold (0.43 log units) above the measured number; the whole stated range lies above it.
By their numbers in this assay, from the lowest: compounds 4 and 2 (each within the scatter of the next); then compounds 3 and 1 (each within the scatter of the next).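

In this assay, hydroxy to methoxy at an unchanged place on the aryl group is now read alone, and it gives a step beyond the scatter (a 4.2-fold lower number from compound 3 to compound 4 (0.62 log units; beyond the scatter)). The place of the methoxy separates the compounds far less, since 3-methoxyphenyl in place of 4-methoxyphenyl stays within the scatter (a 1.8-fold lower number from compound 2 to compound 4 (0.25 log units; within the scatter)), so the gap between compound 2 and compound 3 goes with hydroxy against methoxy rather than with where the group sits. Nothing measured on these compounds accounts for the size of the hydroxy to methoxy step, and the numbers record only that it occurs.

Open, going by these compounds, is whether a longer chain on this oxygen, such as ethoxy, would carry the number further down, or whether an amine or a carboxylic acid at the same place on the aryl group would leave it near the level of the hydroxy compound or move it elsewhere. Also open, on these data alone, is whether the same step holds for 4-hydroxyphenyl to 4-methoxyphenyl, or whether it belongs to the 3-substituted phenyl alone.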